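Swapping 4-fluorophenyl for 3-methylphenyl on the shared core

This account rests on a few compounds, and the source may have more. Where it says the series, first, only, none or still open, it means among the compounds named here.

In a functional assay on KB cells (Homo sapiens) for antiproliferative activity, read by sulforhodamine B assay, with a stated time of 3 days (on this read-out higher numbers stand for an effect only at larger amounts of compound and lower numbers for an effect already at smaller amounts), compound 1 `CCC1=C(O)c2c(oc(-c3ccccc3)cc2=O)C(CC)(CC)C1=O` gives only a limit, > 236 uM. Compound 3 `CCC1=C(O)c2c(oc(-c3ccc(F)cc3)cc2=O)C(CC)(CC)C1=O` gives 33 uM, the higher of the two actual numbers, while compound 2 `CCC1=C(O)c2c(oc(-c3ccc(C(C)C)cc3)cc2=O)C(CC)(CC)C1=O` gives 8.13 uM. Compound 4 `CCC1=C(O)c2c(oc(-c3cccc(C)c3)cc2=O)C(CC)(CC)C1=O` has 3-methylphenyl in place of 4-fluorophenyl (3-methylphenyl in place of 4-fluorophenyl on an aromatic carbon). Within the data shown here, three measured steps bear on this change. Substitution lowered the number in an at least 29-fold lower number from compound 1 to compound 2 (1.46 log units; beyond the scatter) and in an at least 7.1-fold lower number from compound 1 to compound 3 (0.85 log units; beyond the scatter), and the choice of group still mattered in a 4.1-fold higher number from compound 2 to compound 3 (0.61 log units; beyond the scatter). Among the measured compounds shown here, no measured compound carries a methyl group, so the result is expected to stay close to compound 3 at 33 uM, with no shift beyond the scatter. The expected change is a 1.2-fold higher number from compound 3 to compound 4 (0.08 log units; within the scatter) in this assay. The estimate for compound 4 is 40 uM, with an expected range of 12 uM to 150 uM.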

Compound 4, concentration for half-maximal effect: 49.7 uM
For compound 4 the middle estimate is 1.2-fold (0.09 log units) below the measured one, and the stated range covers the measured number.
By their numbers in this assay, from the lowest: compound 2; then compounds 3 and 4 (each within the scatter of the next). At a limit, above all of these: compound 1.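

In this assay, 3-methylphenyl and 4-fluorophenyl on the shared core cannot be told apart, with a 1.5-fold higher number from compound 3 to compound 4 (0.18 log units; within the scatter), so a second kind of substituent in a different ring place gives a similar result. Compound 4 still keeps a gain over the unsubstituted phenyl, with an at least 4.7-fold lower number from compound 1 to compound 4 (0.67 log units; beyond the scatter), but does not match 4-isopropylphenyl, with a 6.1-fold higher number from compound 2 to compound 4 (0.79 log units; beyond the scatter). The comparison with compound 1 rests on a limit: the limit of > 236 uM in this assay, at which 1 of the 4 values shown sits.

The compounds shown do not separate the effect of the group from that of its place on the ring, as 3-methylphenyl and 4-isopropylphenyl differ in both. From the compounds shown here alone, how an amine, a carboxylic acid or a longer alkyl chain on this ring would behave remains open.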